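The compounds below may be only part of what the source reports. "The series", "measured", "known", "first", "only" and "open" are said of these compounds alone.

Measured compounds:
compound 1 `COc1ccc(-c2c(C)cccc2C)cc1COc1ccc(CCC(=O)O)cc1` with 10000 nM
compound 2 `Cc1cc(OC2CCOCC2)cc(C)c1-c1cccc(COc2ccc(CCC(=O)O)c(F)c2)c1` with 6.7 nM

In an assay on CHO cells for displacement of a labelled ligand from Free fatty acid receptor 1 (Rattus norvegicus), read by scintillation counting, with a stated time of 90 min, in the presence of a further agent that is not named here (on this read-out higher numbers stand for weaker inhibition and lower numbers for stronger inhibition), compound 2 gives the lowest of the two numbers, and the gap to compound 1 lies well beyond the usual scatter of such measurements. Compound 3 `Cc1cc(OCC2(O)CCS(=O)(=O)CC2)cc(C)c1-c1cccc(COc2ccc(CCC(=O)O)c(F)c2)c1` has not been measured. It differs from compound 2 in one place: (4-hydroxy-1,1-dioxothian-4-yl)methyl in place of oxan-4-yl on an oxygen on an aromatic ring. Going by the values given here, no measured pair shows a change of this kind here, so the direction cannot be read from these data. The expected step of a 2.2-fold higher number from compound 2 to compound 3 (0.35 log units; beyond the scatter) is small, toward a slightly higher number, within or near the scatter. Compound 3 is estimated at 15 nM, with a plausible range from 4 nM to 60 nM.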

Compound 3, inhibition constant: 8.2 nM
Estimate against measurement, compound 3: 1.8-fold (0.26 log units) above, and the stated range covers the measured number.
By their numbers in this assay, from the lowest: compounds 2 and 3 (each within the scatter of the next); then compound 1.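

Replacing oxan-4-yl with the larger (4-hydroxy-1,1-dioxothian-4-yl)methyl on an oxygen on an aromatic ring gives a 1.2-fold higher number from compound 2 to compound 3 (0.09 log units; within the scatter) in this assay. In this one pair, then, the position accepts a group with more heavy atoms, a hydrogen-bond donor and more hydrogen-bond acceptors, and the number stays within the scatter. No supporting measurements are available to explain this result. The compounds shown leave open what a piperidin-4-yl amine or a plain methyl on that oxygen would give, and whether the hydroxy group of the entering group matters on its own.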